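This account rests on a few compounds, and the source may have more. Where it says the series, first, only, none or still open, it means among the compounds named here.

Compound 3 `CN1CC[N+](C)(CCCCCCCOc2cc(-n3cc(C(=O)Nc4cc(F)cc(F)c4)c(=O)c4ccc(N(C)C)nc43)ccc2Cl)CC1` stands lowest of the three compounds measured in an assay on LX2 cells for inhibition of COL1A1 promoter (Homo sapiens), read by a luciferase reporter, with a stated time of 24 h, tested at 50 uM; a lower number here means a weaker effect, a higher number a stronger effect of the compound at the concentration tested. In this assay compound 3 gives 45.2%. Compound 1 `CN(C)c1ccc2c(=O)c(C(=O)Nc3cc(F)cc(F)c3)cn(-c3ccc(Cl)c(OCCCCCCC[N+]4(C)CCCC4)c3)c2n1` gives 76.1%, and compound 2 `CN(C)c1ccc2c(=O)c(C(=O)Nc3cc(F)cc(F)c3)cn(-c3ccc(Cl)c(OCCCCCCC[n+]4ccccc4)c3)c2n1` gives 77.9%; the step of a number 1.8 percentage points higher from compound 1 to compound 2 (within the scatter) lies within the scatter. Compound 4 `CN(C)c1ccc2c(=O)c(C(=O)Nc3cc(F)cc(F)c3)cn(-c3ccc(Cl)c(OCCCCCCC[N+](C)(C)C4CCCCC4)c3)c2n1` has not yet been measured in this assay. It differs from compound 3 in one place: a group of 9 heavy atoms (8 carbon, 1 nitrogen; one six-membered non-aromatic ring of carbon only) in place of a group of 8 heavy atoms (6 carbon, 2 nitrogen; one six-membered non-aromatic ring with 2 hetero atoms), on a saturated chain carbon, seven bonds along the chain from an oxygen on an aromatic ring. For the measured compounds named here, two measured steps bear on this change, since each of them puts the six-membered non-aromatic ring with 2 hetero atoms in place of a ring with a single nitrogen at the same place on the chain: a number 30.9 percentage points lower from compound 1 to compound 3 (beyond the scatter) and a number 32.7 percentage points lower from compound 2 to compound 3 (beyond the scatter). Compound 4 takes that two-hetero-atom ring away again and carries instead a six-membered non-aromatic ring of carbon only on a charged nitrogen, so the step is expected to run in the opposite direction, large and beyond the scatter, a number 24.8 percentage points higher from compound 3 to compound 4 (beyond the scatter). The group that enters is not the same as the groups found in compound 1 or compound 2, so a full return to their level is not certain. Compound 4 is therefore estimated at 70%, with a range from 50% to 85%.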

Compound 4, a percentage reported as inhibition, at one concentration (the size of the read-out at that concentration, not a potency): 81.4%
Estimate against measurement, compound 4: 11.4 percentage points below, and the stated range covers the measured number.
By their numbers in this assay, from the lowest: compound 3; then compounds 1, 2 and 4 (each within the scatter of the next).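

The change from the ring with 2 hetero atoms to the carbon-only ring on the charged nitrogen gives the largest step seen at this place on the chain in this assay (a number 36.2 percentage points higher from compound 3 to compound 4 (beyond the scatter)). It also shows that the low reading of compound 3 does not simply follow group size, since the entering group of 9 heavy atoms is larger than the 8 heavy atoms that leave, yet the reading rises. The earlier compounds shown here could not show this, as both carried smaller groups of 6 heavy atoms and read higher than compound 3. Compound 4 instead stays level with them (a number 3.5 percentage points higher from compound 2 to compound 4 (within the scatter) and a number 5.3 percentage points higher from compound 1 to compound 4 (within the scatter)), so a five-membered non-aromatic ring, a six-membered aromatic ring and a carbon-only six-membered ring are all tolerated here, and among these four compounds only the ring with 2 hetero atoms in compound 3 stands apart.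

Going by these compounds, whether that low reading belongs to the second ring nitrogen or to the ring as a whole stays open, as does how a morpholine ring or an uncharged tertiary amine at the end of the chain would read. No measurement offered here accounts for the gap between compound 3 and the others.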